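A few compounds are considered here, and "the series" means these few. Any claim that something is new, unique, unknown or untested is made for them only; others in the source may bear on it.

Values in a functional assay on A549 cells (Homo sapiens) for cytotoxicity, read by MTT assay, with a stated time of 72 h; on this read-out higher numbers stand for weaker inhibition and lower numbers for stronger inhibition:
- compound 1 `O=C(Nc1ccc(Oc2ncnc3[nH]ccc23)c(F)c1)c1cc2cccnc2n(-c2ccc(F)cc2)c1=O` gives 5290 nM in this series
- compound 2 `O=C(Nc1ccc(Oc2ncnc3[nH]ccc23)c(F)c1)c1cc2cccnc2n(-c2ccc(Br)cc2)c1=O` gives 27300 nM in this series

Compound 2 holds the higher of the two numbers in this assay and so shows the weaker inhibition of the pair, with the gap to compound 1 beyond the scatter. Compound 3 `O=C(Nc1ccc(Oc2ncnc3[nH]ccc23)c(F)c1)c1cc2cccnc2n(-c2ccc(Br)cc2F)c1=O` differs from compound 2 by fluoro in place of hydrogen on an aromatic carbon and the change is fluoro in place of hydrogen on an aromatic carbon, ortho to a large group and meta to a bromo group, or 4-bromophenyl to 4-bromo-2-fluorophenyl.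

For the measured compounds named here, only one measured step is available, namely a 5.2-fold higher number from compound 1 to compound 2 (0.71 log units; beyond the scatter) as a modest change. It replaces fluoro with bromo and does not replace hydrogen with fluoro, so it bears on the new change only indirectly. Going by the values given here, no measured step tests this change. A small step in this assay is therefore expected, leaning weakly towards a lower number and perhaps staying within the scatter. The expected move is a 1.4-fold lower number from compound 2 to compound 3 (0.16 log units; within the scatter) as a rough estimate. The estimate for compound 3 is 19000 nM with an expected range from 6500 nM to 50000 nM on repeat measurement.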

Compound 3, half-maximal inhibitory concentration: 218000 nM
Estimate against measurement, compound 3: 11-fold (1.06 log units) below; measured number outside the range, above it.
By their numbers in this assay, from the lowest: compound 1; then compound 2; then compound 3.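

In this assay, the position ortho to a large group on the 4-bromophenyl ring proves sensitive to the smallest possible addition: a single fluoro in place of hydrogen gives an 8.0-fold higher number from compound 2 to compound 3 (0.90 log units; beyond the scatter), whereas the earlier pair showed only the exchange of one halogen for another. Read from compound 1, the step to the 4-bromo-2-fluorophenyl group gives a 41-fold higher number from compound 1 to compound 3 (1.62 log units; beyond the scatter), so among these three compounds, bromo in place of fluoro and the added fluoro both move the number towards weaker inhibition, with no compound going against this, and compound 1 stays the strongest of the set. Nothing available accounts for the size of the added fluoro's step, and the data give no cause for it.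

From the compounds shown here alone, it remains open whether the step belongs to fluoro itself or to any substituent on that carbon, which a chloro, methyl or methoxy group there would test. Going by these compounds, it is also open whether the added fluoro gives a similar step on the 4-fluorophenyl ring of compound 1, or whether its size depends on the bromo group.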